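This account rests on a few compounds, and the source may have more. Where it says the series, first, only, none or still open, it means among the compounds named here.

Series on the shared core of compound 3 `CCC1=C(O)c2c(oc(-c3ccccc3C)cc2=O)C(CC)(CC)C1=O`, varied only in the aryl group. In a functional assay on KB cells (Homo sapiens) for antiproliferative activity, read by sulforhodamine B assay, with a stated time of 3 days (on this read-out higher numbers stand for an effect only at larger amounts of compound and lower numbers for an effect already at smaller amounts), compound 3 gives 40.9 uM, the highest of the two numbers available; compound 1 `CCC1=C(O)c2c(oc(-c3ccc(OC)cc3)cc2=O)C(CC)(CC)C1=O` gives 17.7 uM, and a 2.3-fold higher number from compound 1 to compound 3 (0.36 log units; beyond the scatter). Compound 2 `CCC1=C(O)c2c(oc(-c3ccc(CBr)cc3)cc2=O)C(CC)(CC)C1=O` reaches only a limit, > 46.5 uM, as recorded in the limit of > 46.5 uM in this assay, at which 1 of the 3 values shown sits. Compound 4 `CCC1=C(O)c2c(oc(-c3cc(C)c(O)c(C)c3)cc2=O)C(CC)(CC)C1=O` carries the change (4-hydroxy-3,5-dimethylphenyl in place of 2-methylphenyl on an aromatic carbon). Among the measured compounds shown here, the one measured step that bears on it, a 2.3-fold higher number from compound 1 to compound 3 (0.36 log units; beyond the scatter), shows that exchanging 4-methoxyphenyl for 2-methylphenyl raised the number modestly; compound 4 brings an oxygen-bearing aryl group back, so a modest step down beyond the scatter is expected, a 2.0-fold lower number from compound 3 to compound 4 (0.31 log units; beyond the scatter). Compound 4 is therefore estimated at 20 uM, in the range 8 uM to 50 uM.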

Compound 4, concentration for half-maximal effect: 18.3 uM
Beside the measured number, compound 4's estimate is 1.1-fold (0.04 log units) above it; the range from low to high includes it.
By their numbers in this assay, from the lowest: compounds 1 and 4 (each within the scatter of the next); then compound 3. At a limit, above all of these: compound 2.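

In this assay, 4-hydroxy-3,5-dimethylphenyl in place of 2-methylphenyl gives a 2.2-fold lower number from compound 3 to compound 4 (0.35 log units; beyond the scatter), so the higher number seen with 2-methylphenyl does not hold once an oxygen-bearing aryl group returns. Against 4-methoxyphenyl the result is a 1.0-fold higher number from compound 1 to compound 4 (0.01 log units; within the scatter), so the two oxygen-bearing aryl groups are not told apart here. The remaining step, an at least 2.5-fold lower number from compound 2 to compound 4 (0.40 log units; beyond the scatter), starts from a limit: the limit of > 46.5 uM in this assay, at which 1 of the 4 values shown sits.

Whether the hydroxy group or the two methyl groups account for the change stays open. On these data alone, how an amine or a carboxylic acid on the aryl group would read also stays open.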